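Stability notes on the bridged carbapenem series

The source may hold more compounds than are shown below. What is called first, only, known or untested is meant among the compounds shown, and "the series" means these compounds.

Measured compounds:
- compound 1 `C[C@@H](O)[C@H]1C(=O)N2C3=C(S[C@@H]4CN[C@@H](C4)C(=O)Nc4cccc(c4)C(=O)OC/C=C\COC3=O)[C@H](C)[C@H]12`: > 95%
- compound 2 `CCOC(=O)C1=C(S[C@H]2C[C@@H](C(=O)Nc3cccc(C(=O)OCC)c3)N(C(=O)OCc3oc(=O)oc3C)C2)[C@H](C)[C@@H]2[C@@H]([C@@H](C)O)C(=O)N12`: > 95%
- compound 3 `CCCCCCCCCCCCCCCCOC(=O)C1=C(S[C@@H]2CN[C@H](C(=O)Nc3cccc(C(=O)OCCCCCCCCCCCCCCCC)c3)C2)[C@H](C)[C@@H]2[C@@H]([C@@H](C)O)C(=O)N12`: > 95%

Measurement is by a physicochemical assay for metabolic stability, read by LC-MS, in phosphate buffer, with a stated time of 3 h, at pH 7.4, tested at 50 uM; on this read-out higher numbers stand for a more stable compound and lower numbers for a less stable compound. Compound 1 returns only a limit of the assay, > 95%, not a number. Compound 2 likewise reaches a limit, > 95%. Compound 3 also sits at a limit, > 95%. For the measured compounds named here, the whole picture so far is summarised by the limit of > 95% in this assay, at which 3 of the 3 values shown sit; no compound in the set has yet given a number below that ceiling, so no ordering among the three can be read from these values.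

Compound 4 `Cc1oc(=O)oc1COC(=O)N1C[C@@H]2C[C@H]1C(=O)Nc1cccc(c1)C(=O)OC/C=C\COC(=O)C1=C(S2)[C@H](C)[C@@H]2[C@@H]([C@@H](C)O)C(=O)N12` is the next entry. It differs from compound 1 by a group of 11 heavy atoms (6 carbon, 5 oxygen; one five-membered aromatic ring with 2 hetero atoms) in place of a hydrogen atom, on an amine nitrogen in a ring. The same five-membered aromatic ring with two hetero atoms, attached through a carbonyl, occurs on the ring amine nitrogen of compound 2, which gave > 95%.

Going by the values given here, with every measured value at the limit, no step between measured compounds is available, and nothing in the data marks the added group as destabilising under these conditions. The expected step that the limit leaves unreadable from compound 1 to compound 4 is none beyond the scatter. Compound 4 is therefore estimated at 96%, with a range from 88% to 99%.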

Compound 4, percent of the compound remaining: > 95%
Compound 4 ended at the assay's limit; the forecaster's own chance of this, stated with the estimate: 80%; the middle value is on the limit's open side.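

No step can be read from compound 1 to compound 4, as both return only a limit in this assay, not a number: the limit of > 95% in this assay, at which 4 of the 4 values shown sit. The compounds shown leave open whether the group added on the amine nitrogen in a ring changes the percent remaining at all, and how the four compounds rank.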